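This account rests on a few compounds, and the source may have more. Where it says the series, first, only, none or still open, it means among the compounds named here.

Measured so far in a toxicity assay on THP-1 cells (Homo sapiens) for inhibition; a higher number here means that more compound is tolerated, a lower number that less compound is tolerated:
- Compound 1 `Cn1c(-c2ccccc2)cnc1NC(=O)c1ccc(F)cc1`: > 100000 nM, a limit
- Compound 2 `Cn1c(-c2ccccc2)cnc1NC(=O)c1ccccc1Cl`: > 50000 nM, a limit

Compound 2 has no exact value in this assay. Its standing rests on the limit of > 50000 nM. Compound 3 `Cn1c(-c2ccccc2)cnc1NC(=O)c1cccc(Cl)c1` is the next to be tested, and it differs from compound 2 as follows: 3-chlorophenyl in place of 2-chlorophenyl on a carbonyl carbon. The chlorine stays on the ring, with 3-chlorophenyl in place of 2-chlorophenyl on a carbonyl carbon.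

Among the compounds with values here, only one measured step bears on this change, a step that the two limits leave unreadable from compound 1 to compound 2, which also alters the group on that carbonyl carbon. It has no readable size, so it offers no magnitude to carry over. No step beyond the usual scatter is therefore expected in this assay, in either direction.

The estimated step is a step that the limit leaves unreadable from compound 2 to compound 3. Compound 3 is estimated at 80000 nM, with an expected range of 30000 nM to 200000 nM.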

Compound 3, half-maximal cytotoxic concentration: > 50000 nM
Compound 3: only a limit was reported; the forecaster's own chance of this, stated with the estimate: 85%; the middle value lies beyond the limit too.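

In this assay compound 3 gives > 50000 nM, which is a limit. No step can be read among compound 1, compound 2 and compound 3. The compounds shown leave open where each reaches its half-maximal cytotoxic concentration, and whether the group on the carbonyl carbon alters it at all.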